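A few compounds are considered here, and "the series" means these few. Any claim that something is new, unique, unknown or untested is made for them only; others in the source may bear on it.

Measured so far:
compound 1, `Nc1cc(N)c2nc(-c3ccccc3)c(Oc3ccc(Cl)c(Cl)c3)nc2c1`: 91200 nM
compound 2, `CCOC(=O)[C@H](CCC(=O)O)NC(=O)c1ccc(CNc2nc3cc(N)cc(N)c3nc2-c2ccccc2)cc1`: < 100000 nM
compound 3, `CCOC(=O)[C@H](CCC(=O)O)NC(=O)c1ccc(Oc2nc3cc(N)cc(N)c3nc2-c2ccccc2)cc1`: < 100000 nM

Among the measured compounds shown here, in a functional assay on SW-620 cells (Homo sapiens) for inhibition, read by sulforhodamine B assay, with a stated time of 48 h (on this read-out lower numbers stand for higher toxicity in this test and higher numbers for lower toxicity in this test), compound 1 gives 91200 nM, the only plain number in this set. For compound 2 the entry < 100000 nM is a limit of the test, not a number. For compound 3 the entry < 100000 nM is likewise a limit. Where the set sits is summed up by the limit of < 100000 nM in this assay, at which 2 of the 3 values shown sit. Compound 4, `Nc1cc(N)c2nc(-c3ccccc3)c(NCc3ccc(F)cc3)nc2c1`, differs from compound 1 by (4-fluorobenzyl)amino in place of 3,4-dichlorophenoxy on an aromatic carbon. For the measured compounds named here, no measured pair in this set tracks such a change, so in this assay the expected step of a 1.1-fold lower number from compound 1 to compound 4 (0.06 log units; within the scatter) is none beyond the scatter, in either direction. For compound 4 the estimate is therefore 80000 nM, with a range from 25000 nM to 150000 nM.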

Compound 4, concentration lethal to 50% of the cells: < 100000 nM
Compound 4: only a limit was reported; the forecaster's own chance of this, stated with the estimate: 35%; the middle value lies beyond the limit too.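

In this assay, among the compounds shown here, compound 4 gives < 100000 nM, a limit and not a number, so no step from compound 1 to compound 4 can be read. The compounds shown leave open whether (4-fluorobenzyl)amino in place of 3,4-dichlorophenoxy shifts the result in this assay, and in which direction.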